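This account rests on a few compounds, and the source may have more. Where it says the series, first, only, none or still open, it means among the compounds named here.

Measured so far:
compound 1 `COc1ccc(-c2cc(/C=C/C(=O)c3ccc(N)cc3)[nH]n2)cc1`: -60%
compound 2 `COc1cc(-c2cc(/C=C/C(=O)c3ccc(N)cc3)[nH]n2)cc(OC)c1OC`: -57%

In a functional assay on SK-MEL-28 cells (Homo sapiens) for cytotoxicity, read by sulforhodamine B assay, with a stated time of 48 h, tested at 10 uM (a higher number here means a weaker effect of the compound at the concentration tested, a lower number a stronger effect), compound 1 gives -60%. In this assay compound 2 gives -57%. Compound 2 stands at the top of these two numbers, but compound 1 lies within the usual scatter of it, so the two values cannot be told apart. Within the data shown here, no step between measured compounds that differ in one place is available from this pair. Compound 3 `COc1ccc(-c2cc(/C=C/C(=O)c3ccc(N)cc3)[nH]n2)cc1OC` has not yet been measured. It differs from compound 2 in one place: hydrogen in place of methoxy on an aromatic carbon. Since compound 1 and compound 2, which differ in the same region, give values within the scatter of each other, no step beyond the scatter is expected for a number 1 percentage points lower from compound 2 to compound 3 (within the scatter). Compound 3 is therefore estimated at -58%, with a range from -78% to -38%.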

Compound 3, a percentage reported as activity, at one concentration (the size of the read-out at that concentration, not a potency): -29%
The estimate for compound 3 lay 29 percentage points below the measured number; measured number above the stated range.
By their numbers in this assay, from the lowest: compounds 1 and 2 (each within the scatter of the next); then compound 3.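

In this assay, the methoxy pattern on the six-membered aromatic ring of carbon only matters in a way that the first two values did not reveal. Hydrogen in place of methoxy gives a number 28 percentage points higher from compound 2 to compound 3 (beyond the scatter), and methoxy in place of hydrogen gives a number 31 percentage points higher from compound 1 to compound 3 (beyond the scatter), so opposite changes on this ring both end at the weaker effect of compound 3, and the closeness of compound 1 and compound 2 cannot be read as general tolerance of change on this ring. Nothing at hand offers an explanation for this result.

From the compounds shown here alone, whether a hydroxy group, a fluorine atom or an amine on the aromatic carbon that carries hydrogen in compound 3 would restore the stronger effect remains open. Going by these compounds, it is also open whether this dependence on the methoxy pattern would persist with changes elsewhere on the shared core.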